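Side-chain amine change from compound 3 to compound 4

A few compounds are considered here, and "the series" means these few. Any claim that something is new, unique, unknown or untested is made for them only; others in the source may bear on it.

In a functional assay on HL60/MX2 cells (Homo sapiens) for antiproliferative activity, read by MTT assay, with a stated time of 48 h (on this read-out lower numbers stand for stronger inhibition and higher numbers for weaker inhibition), compound 1 (`CN(C)CCn1c(N)c(-c2nc3ccccc3[nH]2)c2nc(C#N)c(C#N)nc21`) gives 3780 nM and compound 3 (`CN1CCN(CCn2c(N)c(-c3nc4ccccc4[nH]3)c3nc(C#N)c(C#N)nc32)CC1`) gives 6490 nM so these two stand together, with a 1.7-fold higher number from compound 1 to compound 3 (0.23 log units; within the scatter) as their step. Compound 2 (`N#Cc1nc2c(-c3nc4ccccc4[nH]3)c(N)n(CCN3CCCC3)c2nc1C#N`) reaches only a limit of the assay at > 50000 nM and gives no number. The steps of an at least 13-fold higher number from compound 1 to compound 2 (1.12 log units; beyond the scatter) and an at least 7.7-fold lower number from compound 2 to compound 3 (0.88 log units; beyond the scatter) both rest on that limit. Compound 4 (`CCN(CC)CCCn1c(N)c(-c2nc3ccccc3[nH]2)c2nc(C#N)c(C#N)nc21`) differs by (diethylamino)methyl in place of 4-methylpiperazin-1-yl on a saturated chain carbon, two bonds along the chain from an aromatic nitrogen and carries 3-(diethylamino)propyl in place of 2-(4-methylpiperazin-1-yl)ethyl. The amine swaps at this place bear on it, though none also alters the chain. The small step between compound 1 and compound 3 sets the expectation, and the large steps involving compound 2 widen the range. In this assay the expected step is a 1.3-fold lower number from compound 3 to compound 4 (0.11 log units; within the scatter) (none beyond the scatter). Compound 4 is estimated at 5000 nM (range 1500 nM to 25000 nM).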

Compound 4, half-maximal inhibitory concentration: 1820 nM
The estimate for compound 4 lay 2.7-fold (0.44 log units) above the measured number; measured number inside the range.
By their numbers in this assay, from the lowest: compound 4; then compounds 1 and 3 (each within the scatter of the next). At a limit, above all of these: compound 2.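

In this assay, within the data shown here, 3-(diethylamino)propyl gives the first steps between numbers at this place that fall beyond the scatter in the lowering direction: a 3.6-fold lower number from compound 3 to compound 4 (0.55 log units; beyond the scatter) and a 2.1-fold lower number from compound 1 to compound 4 (0.32 log units; beyond the scatter). Compound 2 gives only a limit, and an at least 27-fold lower number from compound 2 to compound 4 (1.43 log units; beyond the scatter) rests on it: the limit of > 50000 nM in this assay, at which 1 of the 4 values shown sits. Compound 4 changes both the amine and the chain, so these steps tie neither to one alone.

Still open, from the compounds shown here alone, is how much of the lowering belongs to the diethylamino group and how much to the longer chain. A 2-(diethylamino)ethyl or 3-(dimethylamino)propyl group on the shared core would bear on this.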